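Adding one methoxy group to compound 3

The compounds below may be only part of what the source reports. "The series", "measured", "known", "first", "only" and "open" are said of these compounds alone.

- Compound 1 `COc1cccc(/C=C2\CCC/C(=C\c3ccccc3Cl)C2=O)c1OC`: > 20000 nM (a limit of the assay)
- Compound 2 `COc1cccc(/C=C2\CCC/C(=C\c3cccc(Br)c3)C2=O)c1OC`: > 20000 nM (a limit of the assay)
- Compound 3 `COc1cccc(/C=C2\CCC/C(=C\c3cccc(OC)c3OC)C2=O)c1`: 16400 nM

Among the compounds with values here, in a functional assay on A549 cells (Homo sapiens) for cytotoxicity, read by MTT assay, with a stated time of 72 h (a higher number here means a weaker inhibitor, a lower number a stronger inhibitor), compound 3 gives 16400 nM, the only true number so far. The other two results are limits, and (the limit of > 20000 nM in this assay, at which 2 of the 3 values shown sit).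

Compound 4 `COc1cc(/C=C2\CCC/C(=C\c3cccc(OC)c3OC)C2=O)cc(OC)c1` differs from compound 3 in one place, with methoxy in place of hydrogen on an aromatic carbon.

Within the data shown here, no measured step makes this exact change. The nearest is an at least 1.2-fold lower number from compound 2 to compound 3 (0.08 log units; that floor lies within the scatter), which puts methoxy in place of bromo on an aromatic carbon. The other is an at least 1.2-fold lower number from compound 1 to compound 3 (0.08 log units; that floor lies within the scatter). Both give only a floor, so neither shows a real effect of methoxy. No step beyond the scatter is therefore expected in this assay, and compound 4 could also end up as a limit. The expected change is a 1.1-fold lower number from compound 3 to compound 4 (0.04 log units; within the scatter). For compound 4 the estimated value is 15000 nM, within an expected range of 7000 nM to 30000 nM.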

Compound 4, half-maximal inhibitory concentration: 10200 nM
Compound 4: the middle estimate sits 1.5-fold (0.17 log units) above what was measured; low and high end bracket the measured number.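

Compound 4 gives a second true number in this assay, so a step can now be read at its full size rather than only as a floor: a 1.6-fold lower number from compound 3 to compound 4 (0.21 log units; within the scatter). Methoxy in place of hydrogen at this position, on an aromatic carbon meta to a large group and meta to a methoxy group, therefore leaves the result within the scatter, and the added group neither clearly helps nor clearly harms here. The earlier comparisons shown here gave only floors, and limits still mark this small set: the limit of > 20000 nM in this assay, at which 2 of the 4 values shown sit.

From the compounds shown here alone, whether this position would respond differently to another group, such as an amine or a carboxylic acid, stays open. Within the data shown here, also open is whether any change on this ring can produce a step beyond the scatter, since the one readable step stays within it.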